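The source may report more compounds than this note shows. Statements on the series, on what has been measured and on what is new or still open speak of the compounds shown alone.

In a functional assay on HCT-116 cells (Homo sapiens) for antiproliferative activity, read by MTT assay, with a stated time of 72 h (a lower number here means a stronger inhibitor, a higher number a weaker inhibitor), compound 1 `O=C1COc2ccc(-c3cccc(NS(=O)(=O)c4ccc(F)cc4)c3)cc2N1` gives > 40000 nM, which is a limit of the assay and not a number. Among the compounds with values here, compound 2 `COc1ccc(N2C(=O)COc3ccc(-c4cccc(NS(=O)(=O)c5ccc(F)cc5)c4)cc32)cc1` gives 28300 nM, the only true number so far. Compound 3 `O=C1COc2ccc(-c3cccc(NS(=O)(=O)c4ccc(F)cc4)c3)cc2N1C1CCCCC1` shares the core of compound 2 and differs from it by cyclohexyl in place of 4-methoxyphenyl on an amide-type nitrogen in a ring, with cyclohexyl in place of 4-methoxyphenyl on the amide-type nitrogen in a ring. Within the data shown here, the only measured step at that nitrogen is an at least 1.4-fold lower number from compound 1 to compound 2 (0.15 log units; that floor lies within the scatter), which installs the 4-methoxyphenyl in place of hydrogen. With that one open-ended step as the guide, no change beyond the scatter is expected in this assay, though a further limit reading remains possible. The expected step is a 1.1-fold higher number from compound 2 to compound 3 (0.03 log units; within the scatter). For compound 3 the estimated value is 30000 nM, with an expected range from 12000 nM to 60000 nM.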

Compound 3, half-maximal inhibitory concentration: 18300 nM
Estimate against measurement, compound 3: 1.6-fold (0.21 log units) above; the range from low to high includes it.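

Within the data shown here, at the amide-type nitrogen in a ring, cyclohexyl in place of hydrogen gives the first step beyond the scatter in this assay: an at least 2.1-fold lower number from compound 1 to compound 3 (0.33 log units; beyond the scatter). The size of that step is only a floor, because compound 1 stands at a limit and not at a number: the limit of > 40000 nM in this assay, at which 1 of the 3 values shown sits. A non-aromatic ring also serves at this nitrogen, as the exchange of 4-methoxyphenyl for cyclohexyl gives a 1.5-fold lower number from compound 2 to compound 3 (0.19 log units; within the scatter), so compound 2 and compound 3 cannot be told apart here.

From the compounds shown here alone, it remains open whether a small group such as methyl, or a longer chain ending in an amine, would do the same at this nitrogen. Going by these compounds, how far any group at this place can lower the number also remains open.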